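A Third Methoxy on Two Chalcone Cores

A few compounds are considered here, and "the series" means these few. Any claim that something is new, unique, unknown or untested is made for them only; others in the source may bear on it.

Compound 2 `COc1cc(/C=C/C(=O)c2ccccc2F)cc(OC)c1` gives 62.9 nM in a functional assay on HeLa cells (Homo sapiens) for cytotoxicity, read by MTT assay, with a stated time of 72 h; on this read-out lower numbers stand for stronger inhibition and higher numbers for weaker inhibition. Compound 1 `COc1cc(/C=C/C(=O)c2ccccc2F)cc(OC)c1OC` differs from it by a single change, (methoxy in place of hydrogen on an aromatic carbon), and the result is a 3.6-fold higher number from compound 2 to compound 1 (0.56 log units; beyond the scatter). In this assay compound 1 gives 228 nM. Compound 3 `COc1ccc(C(=O)/C=C/c2ccc(OC)cc2OC)c(F)c1` rests on a different core; the difference between the two cores is not broken down here. In this assay compound 3 gives 260 nM. Compound 4 `COc1ccc(C(=O)/C=C/c2c(OC)cc(OC)cc2OC)c(F)c1` is not yet measured and differs from compound 3 by methoxy in place of hydrogen on an aromatic carbon. Going by the values given here, this is the same kind of change as the one from compound 2 to compound 1, though here the entering methoxy is ortho to a large group and meta to two methoxy groups, whereas before it was ortho to two methoxy groups and para to a large group. Among the compounds with values here, with only that one earlier step to rest on, a step of similar size is expected, a 3.1-fold higher number from compound 3 to compound 4 (0.49 log units; beyond the scatter). Compound 4 is therefore estimated at 800 nM in this assay, with a likely range from 250 nM to 2600 nM.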

Compound 4, half-maximal inhibitory concentration: > 100000 nM
Compound 4 was reported as a limit; the forecaster's own chance of this, stated with the estimate: 5%; middle value at least 120-fold (2.09 log units) from the limit.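

In this assay, methoxy in place of hydrogen on an aromatic carbon gives an at least 380-fold higher number from compound 3 to compound 4 (2.58 log units; beyond the scatter), so the size of the step did not carry over from one core to the other: the same change on two cores in this assay, a 3.6-fold higher number (0.56 log units; beyond the scatter) from compound 2 to compound 1 and an at least 380-fold higher number (2.58 log units; beyond the scatter) from compound 3 to compound 4, at least 100-fold (2.02 log units) apart, beyond the scatter of two such steps The value of compound 4, > 100000 nM, is a limit of the assay and not a number: the limit of > 100000 nM in this assay, at which 1 of the 4 values shown sits. Both steps point the same way, but two steps on two cores do not show which difference between the cores or in the place of the entering methoxy accounts for the gap, and they give no rule for any other core.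

The compounds shown leave open how a hydroxyl or an amine on that same aromatic carbon would read in this assay. They also leave open whether an ethoxy there would behave like the methoxy.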